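The compounds below may be only part of what the source reports. "The series", "measured", "known", "first", "only" and "open" are said of these compounds alone.

Among the measured compounds shown here, in a functional assay on HCT-116 cells (Homo sapiens) for antiproliferative activity, read by MTT assay, with a stated time of 72 h (on this read-out higher numbers stand for weaker inhibition and lower numbers for stronger inhibition), two compounds on one shared core have numbers so far. Compound 1 `O=C(CCc1cccc2c1B(O)OC2)Nc1cccc(I)c1` gives 2300 nM and compound 2 `O=C(CCc1cccc2c1B(O)OC2)Nc1cccc(-c2ccc(F)cc2)c1` gives 550 nM as the lower of the two numbers, which makes it the stronger inhibitor of this pair. For the measured compounds named here, the single measured step is a 4.2-fold lower number from compound 1 to compound 2 (0.62 log units; beyond the scatter) and comes with 4-fluorophenyl in place of iodo on an aromatic carbon. The change to compound 3 `COc1cc(OC)cc(-c2cccc(NC(=O)CCc3cccc4c3B(O)OC4)c2)c1` is 3,5-dimethoxyphenyl in place of 4-fluorophenyl on an aromatic carbon and amounts to 3,5-dimethoxyphenyl in place of 4-fluorophenyl on an aromatic carbon. Going by the values given here, the one measured step bears on this only indirectly. Among the compounds with values here, it replaced iodo, whereas here one aromatic ring replaces another, and no measured pair compares two such rings. The data therefore give no direction, so in this assay the expectation is no step beyond the scatter, although a shift of similar modest size either way remains possible. The expected step is a 1.1-fold higher number from compound 2 to compound 3 (0.04 log units; within the scatter) in this estimate. Compound 3 is estimated at 600 nM with a range from 220 nM to 1600 nM for its measurement.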

Compound 3, half-maximal inhibitory concentration: 53 nM
The estimate for compound 3 lay 11-fold (1.05 log units) above the measured number, and the stated range ends above it.
By their numbers in this assay, from the lowest: compound 3; then compound 2; then compound 1.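

In this assay, the earlier step showed only that 4-fluorophenyl gives a lower number than iodo at this position, but the new result shows that the choice of aromatic ring also matters: with one six-membered aromatic ring of carbon only both leaving and entering, 3,5-dimethoxyphenyl in place of 4-fluorophenyl brings a 10-fold lower number from compound 2 to compound 3 (1.02 log units; beyond the scatter). Set against iodo, the same group gives a 43-fold lower number from compound 1 to compound 3 (1.64 log units; beyond the scatter), which makes compound 3 the strongest inhibitor of the three, with steps to both others beyond the scatter. The entering group differs from 4-fluorophenyl in its heavy atoms and in carrying hydrogen-bond acceptors, but nothing given here separates these differences or accounts for the size of the step.

The compounds shown leave open whether both methoxy groups are needed, since a phenyl ring with a single methoxy group would separate the contribution of each, and whether hydroxy or dimethylamino groups could stand in their place. They also leave open whether the step would carry over to a pyridine ring at this position or to a longer chain on the amide side of the shared core.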